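Carboxy to 1H-tetrazol-5-yl: clearance working notes

This account rests on a few compounds, and the source may have more. Where it says the series, first, only, none or still open, it means among the compounds named here.

In an in vitro ADME assay on microsomes from liver (Homo sapiens) for metabolic stability (on this read-out higher numbers stand for fast clearance and lower numbers for slow clearance), compound 1 `O=C(O)c1ccc(NC(=O)[C@H](CC2CCCC2)n2cnc(C(F)(F)F)c2)nc1` gives < 8 mL/min/kg, which is a limit and not a number. Compound 2 `O=C(O)c1ccnc(NC(=O)[C@H](CC2CCCC2)n2cnc(C(F)(F)F)c2)c1` gives < 8 mL/min/kg, also a limit. Compound 3 `O=C(O)Cc1ccc(NC(=O)[C@H](CC2CCCC2)n2cnc(C(F)(F)F)c2)nc1` gives < 8 mL/min/kg, again a limit. Compound 4 `O=C(Nc1ccc(-c2nnn[nH]2)cn1)[C@H](CC1CCCC1)n1cnc(C(F)(F)F)c1` carries 1H-tetrazol-5-yl in place of carboxy on an aromatic carbon. Among the measured compounds shown here, two measured steps bear on this change: a step that the two limits leave unreadable from compound 1 to compound 2 and a step that the two limits leave unreadable from compound 1 to compound 3. For the measured compounds named here, neither offers a readable size, and the series so far rests on (the limit of < 8 mL/min/kg in this assay, at which 3 of the 3 values shown sit). The expectation in this assay is therefore no step beyond the scatter, in either direction. The expected step is a number no lower from compound 1 to compound 4 (the limit leaves the size open). Compound 4 is estimated at 8 mL/min/kg, with an expected range of 5 mL/min/kg to 14 mL/min/kg.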

Compound 4, clearance: 160 mL/min/kg
The estimate for compound 4 lay 20-fold (1.30 log units) below the measured number; measured number outside the range, above it.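

In this assay, among the compounds shown here, this aromatic carbon gives the first readable change, with 1H-tetrazol-5-yl in place of carboxy giving an at least 20-fold higher number from compound 1 to compound 4 (1.30 log units; beyond the scatter). In place of carboxymethyl, the same group gives an at least 20-fold higher number from compound 3 to compound 4 (1.30 log units; beyond the scatter), so the read-out at this position responds strongly to the group it carries. The steps among the earlier compounds cannot be read, and the low end of the series remains a limit and not a number: the limit of < 8 mL/min/kg in this assay, at which 3 of the 4 values shown sit.

As far as these compounds go, it remains open whether the rise belongs to 1H-tetrazol-5-yl itself or to the loss of carboxy. A primary amide or a nitrile on the same aromatic carbon could separate these two readings.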